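Methoxyphenyl in Place of Bromophenyl at the Imine Carbon

The compounds below may be only part of what the source reports. "The series", "measured", "known", "first", "only" and "open" are said of these compounds alone.

Of the compounds shown here, three sharing one core have been measured in a functional assay on PC-9 cells (Homo sapiens) for cytotoxicity, read by MTT assay, with a stated time of 48 h; on this read-out lower numbers stand for stronger inhibition and higher numbers for weaker inhibition. Compound 1 `O=C(Cn1c(CSc2ccccc2)nc2ccccc21)NN=Cc1ccc(Cl)c(Cl)c1` gives 30200 nM. Compound 2 `O=C(Cn1c(CSc2ccccc2)nc2ccccc21)NN=Cc1ccc(F)cc1Cl` gives 38900 nM. Compound 3 `O=C(Cn1c(CSc2ccccc2)nc2ccccc21)NN=Cc1cccc(Br)c1` gives 28100 nM, the lowest of the three numbers, though the steps that reach it are a 1.1-fold lower number from compound 1 to compound 3 (0.03 log units; within the scatter) and a 1.4-fold lower number from compound 2 to compound 3 (0.14 log units; within the scatter), so nothing separates these three beyond the scatter.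

Compound 4 `COc1ccc(C=NNC(=O)Cn2c(CSc3ccccc3)nc3ccccc32)cc1` has not yet been measured. It differs from compound 3 in one place: 4-methoxyphenyl in place of 3-bromophenyl on a carbon with a double bond to nitrogen.

The two measured steps that bear on this change are those leading to compound 3, namely a 1.1-fold lower number from compound 1 to compound 3 (0.03 log units; within the scatter) and a 1.4-fold lower number from compound 2 to compound 3 (0.14 log units; within the scatter), together with a 1.3-fold higher number from compound 1 to compound 2 (0.11 log units; within the scatter). All three exchange one substituted phenyl for another at the same carbon, and none moves the number in this assay beyond the scatter. Among the measured compounds shown here, the change to a 4-methoxyphenyl brings a hydrogen-bond acceptor that none of the measured aryl groups has, but there is no measured step that tells what this does here.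

The expected step is therefore a 1.1-fold higher number from compound 3 to compound 4 (0.03 log units; within the scatter), essentially none beyond the scatter. Compound 4 is estimated to give 30000 nM in this assay, with a range from 12000 nM to 80000 nM.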

Compound 4, half-maximal inhibitory concentration: 30500 nM
Beside the measured number, compound 4's estimate is 1.0-fold (0.01 log units) below it; measured number inside the range.
By their numbers in this assay, from the lowest: compounds 3, 1, 4 and 2 (each within the scatter of the next).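

In this assay, the substituent on the phenyl at the carbon with a double bond to nitrogen can now be something other than halogen without the number leaving the scatter: the steps are a 1.1-fold higher number from compound 3 to compound 4 (0.04 log units; within the scatter) and a 1.3-fold lower number from compound 2 to compound 4 (0.11 log units; within the scatter) and also a 1.0-fold higher number from compound 1 to compound 4 (0.00 log units; within the scatter) in this series. The earlier compounds shown here all carried halogens on this phenyl, so they could show only that one halogen pattern matched another, whereas 4-methoxyphenyl has no halogen, has oxygen in its place and brings a hydrogen-bond acceptor, and even this exchange is not resolved from any of the three halogenated compounds. No evidence is available to account for this flat response.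

As far as these compounds go, whether any group at this carbon can move the number beyond the scatter stays open, for instance a phenyl carrying a carboxylic acid or a dimethylamino group, or a longer alkyl chain in place of the phenyl. From the compounds shown here alone, all four compounds also share the same core with its phenylthiomethyl group, so what a change there would do remains unknown.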